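The source may report more compounds than this note shows. Statements on the series, on what has been measured and on what is new or still open speak of the compounds shown alone.

Going by the values given here, in a functional assay on UACC-257 cells (Homo sapiens) for inhibition (on this read-out lower numbers stand for stronger inhibition of growth and higher numbers for weaker inhibition of growth), two compounds have numbers so far. Compound 1 `NC(=O)c1cc(Cl)ccc1NC(=O)COc1ccccc1` gives 100000 nM, and compound 2 `NC(=O)c1cc(I)ccc1NC(=O)COc1ccccc1` gives 41700 nM, the lower of the two numbers. Among the compounds with values here, the one measured step, with iodo in place of chloro on an aromatic carbon, is a 2.4-fold lower number from compound 1 to compound 2 (0.38 log units; beyond the scatter), a modest move beyond the scatter. Compound 3 `COc1ccc(NC(=O)COc2ccccc2)c(C(N)=O)c1` carries methoxy in place of iodo at that same carbon: methoxy in place of iodo on an aromatic carbon. Within the data shown here, no measured compound bears methoxy, so the only guide is that single step, which shows that this position can move this assay modestly. Compound 2 holds its lead over compound 1 only by a 2.4-fold lower number from compound 1 to compound 2 (0.38 log units; beyond the scatter), and a modest move back towards weaker inhibition is therefore expected, with a 2.0-fold higher number from compound 2 to compound 3 (0.31 log units; beyond the scatter) as the estimated step. For compound 3 the estimate is 85000 nM, within an expected range of 40000 nM to 130000 nM.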

Compound 3, concentration for 50% growth inhibition: > 100000 nM
Compound 3: only a limit was reported; the forecaster's own chance of this, stated with the estimate: 35%; middle value at least 1.1-fold (0.07 log units) away from the limit.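

Methoxy in place of iodo on this aromatic carbon gives an at least 2.3-fold higher number from compound 2 to compound 3 (0.37 log units; beyond the scatter), so the position now shows a move towards weaker inhibition with a group other than a halogen, and iodo keeps the lowest number of the three groups shown. In this assay compound 3 gives > 100000 nM, which is a limit of the assay and not a number. Methoxy in place of chloro gives a number no lower from compound 1 to compound 3 (the limit leaves the size open), so this step cannot be read and those two groups cannot be placed in order: the limit of > 100000 nM in this assay, at which 1 of the 3 values shown sits.

The compounds shown leave open how a bromo group or an amine at this carbon would compare with iodo in this assay. They also leave open whether a carboxylic acid in place of the carbamoyl group would change the growth inhibition seen with the shared core.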